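Cyano for Trifluoromethyl on a Benzofuran Piperazine Sulfonamide

The source may report more compounds than this note shows. Statements on the series, on what has been measured and on what is new or still open speak of the compounds shown alone.

Measured compounds:
Compound 1 `CCN(CC)c1ccc2cc(C(=O)c3ccc(N4CCN(C(=O)CN5CCN(C(=O)CCl)CC5)CC4)cc3)oc2c1` — 1630 nM
Compound 2 `CCN(CC)c1ccc2cc(C(=O)c3ccc(N4CCN(C(=O)CN5CCN(S(=O)(=O)c6ccc(C(F)(F)F)cc6)CC5)CC4)cc3)oc2c1` — > 40000 nM

Compound 1 has the structure `CCN(CC)c1ccc2cc(C(=O)c3ccc(N4CCN(C(=O)CN5CCN(C(=O)CCl)CC5)CC4)cc3)oc2c1` and in a functional assay on SGC-7901 cells (Homo sapiens) for cytotoxicity, read by MTT assay, with a stated time of 48 h (on this read-out lower numbers stand for stronger inhibition and higher numbers for weaker inhibition), compound 1 gives 1630 nM. Compound 2, with the structure `CCN(CC)c1ccc2cc(C(=O)c3ccc(N4CCN(C(=O)CN5CCN(S(=O)(=O)c6ccc(C(F)(F)F)cc6)CC5)CC4)cc3)oc2c1`, is recorded only as a limit: in this assay compound 2 gives > 40000 nM, which is the limit of the assay and not a measured number (the limit of > 40000 nM in this assay, at which 1 of the 2 values shown sits). For the measured compounds named here, the two values therefore show a weaker response for compound 2 than for compound 1, but no step between them can be sized.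

Compound 3, the structure `CCN(CC)c1ccc2cc(C(=O)c3ccc(N4CCN(C(=O)CN5CCN(S(=O)(=O)c6ccc(C#N)cc6)CC5)CC4)cc3)oc2c1`, is not yet measured. It differs from compound 2 in one place: cyano in place of trifluoromethyl on an aromatic carbon. Going by the values given here, with no measured step of this kind available, the expectation is for little movement, none beyond the scatter, and a fair chance that this assay again reports only a limit. Compound 3 is therefore expected to give about 30000 nM, with a range from 6000 nM to 100000 nM, corresponding to an estimated step of an at least 1.3-fold lower number from compound 2 to compound 3 (0.12 log units; that floor lies within the scatter).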

Compound 3, half-maximal inhibitory concentration: > 40000 nM
Compound 3: a limit, no number; the forecaster's own chance of this, stated with the estimate: 55%; middle value at least 1.3-fold (0.12 log units) away from the limit.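

In this assay compound 3 is again recorded only as a limit and not as a number, so cyano in place of trifluoromethyl on the aromatic carbon does not bring the response into the readable range. The step between these two sulfonamides cannot be read because both sit at the same limit: the limit of > 40000 nM in this assay, at which 2 of the 3 values shown sit. With (4-cyanophenyl)sulfonyl in place of (chloromethyl)carbonyl on the ring amine nitrogen, the change gives an at least 24-fold higher number from compound 1 to compound 3 (1.38 log units; beyond the scatter) and so the weak response now holds for two arylsulfonyl groups, not for the 4-(trifluoromethyl)phenyl one alone.

On these data alone, whether trifluoromethyl and cyano differ at all remains open, since neither gives a number here. As far as these compounds go, it is also open whether an amine or a carboxylic acid at this place on the ring, or a methyl group in place of the whole aryl group on the sulfonyl, would return a readable value.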